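Phenylsulfonyl on the aromatic nitrogen of compound 2

A few compounds are considered here, and "the series" means these few. Any claim that something is new, unique, unknown or untested is made for them only; others in the source may bear on it.

Compound 1 `Cc1ccc(-c2nn(-c3ccccc3)cc2-c2nc3ccccc3[nH]2)cc1` gives 4010 nM
Compound 2 `FC(F)(F)c1ccc(-c2nn(-c3ccccc3)cc2-c2nc3ccccc3[nH]2)cc1` gives 3620 nM
Compound 3 `O=S(=O)(c1ccc(Cl)cc1)n1c(-c2cn(-c3ccccc3)nc2-c2ccc(F)cc2)nc2ccccc21` gives 3170 nM

In a functional assay on A549 cells (Homo sapiens) for antiproliferative activity, read by MTT assay, with a stated time of 24 h (a lower number here means a stronger inhibitor, a higher number a weaker inhibitor), compound 2 gives 3620 nM, within the scatter of both compound 1 and compound 3. Compound 4 `O=S(=O)(c1ccccc1)n1c(-c2cn(-c3ccccc3)nc2-c2ccc(C(F)(F)F)cc2)nc2ccccc21` is not yet measured. It carries phenylsulfonyl in place of hydrogen on an aromatic nitrogen. Among the compounds with values here, no measured step covers this change. Within the data shown here, the single step, a 1.1-fold lower number from compound 1 to compound 2 (0.04 log units; within the scatter), concerns trifluoromethyl in place of methyl. Compound 3, at 3170 nM, also bears a sulfonyl group on an aromatic nitrogen, though it differs elsewhere too. In this assay an estimated 1.2-fold lower number from compound 2 to compound 4 (0.08 log units; within the scatter) is therefore expected, no step beyond the scatter. For compound 4 the estimated value is 3000 nM, with an expected range of 1500 nM to 6000 nM.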

Compound 4, half-maximal inhibitory concentration: 480 nM
Estimate against measurement, compound 4: 6.3-fold (0.80 log units) above; measured number below the stated range.
By their numbers in this assay, from the lowest: compound 4; then compounds 3, 2 and 1 (each within the scatter of the next).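

In this assay phenylsulfonyl in place of hydrogen on the aromatic nitrogen gives a 7.5-fold lower number from compound 2 to compound 4 (0.88 log units; beyond the scatter) and so goes beyond the scatter, unlike the earlier change of methyl to trifluoromethyl. Within the data shown here, this nitrogen is thus a place where the read-out responds to substitution, which the earlier compounds did not show on their own. Nothing measured here explains the shift. On these data alone, how a methylsulfonyl or an acetyl group on this nitrogen would compare with phenylsulfonyl stays open. So does the effect of an amine on the ring of the phenylsulfonyl group.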